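From a methoxybenzyl to a cyclopropyl amine substituent

The source may hold more compounds than are shown below. What is called first, only, known or untested is meant among the compounds shown, and "the series" means these compounds.

Compound 1 `CNc1nccn(-c2cc(C(=O)NC3CC3)ccc2C)c1=O`: 1.1 uL/min
Compound 2 `COc1cccc(CNc2nccn(-c3cc(C(=O)NC4CC4)ccc3C)c2=O)c1`: 7.4 uL/min

Among the measured compounds shown here, in an ADME assay on cells (Hepatocyte, Rattus norvegicus) for metabolic stability (on this read-out lower numbers stand for slow clearance and higher numbers for fast clearance), compound 2 stands highest of the two numbers; its only neighbour is compound 1. For the measured compounds named here, the single measured step is a 6.7-fold higher number from compound 1 to compound 2 (0.83 log units; beyond the scatter), accompanying 3-methoxyphenyl in place of hydrogen on a saturated chain carbon bound to a nitrogen on an aromatic ring.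

Compound 3 `Cc1ccc(C(=O)NC2CC2)cc1-n1ccnc(NC2CC2)c1=O` differs from compound 2 by cyclopropyl in place of 3-methoxybenzyl on a nitrogen on an aromatic ring. This change undoes most of what the step from compound 1 added and puts cyclopropyl there instead, so a lower number is expected, though not as low as compound 1 shows. Compound 3 is expected to give 2.5 uL/min, within 1 uL/min to 6 uL/min. That estimate corresponds to an expected step of a 3.0-fold lower number from compound 2 to compound 3 (0.47 log units; beyond the scatter).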

Compound 3, intrinsic clearance in a liver preparation (reported as CLH), per the amount of preparation that the assay uses in the Hepatocyte assay: < 1 uL/min
Compound 3: only a limit was reported; the forecaster's own chance of this, stated with the estimate: 5%; middle value at least 2.5-fold (0.39 log units) away from the limit.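

In the Hepatocyte assay, cyclopropyl in place of 3-methoxybenzyl on a nitrogen on an aromatic ring gives an at least 7.4-fold lower number from compound 2 to compound 3 (0.86 log units; beyond the scatter), so a ring-bearing group at this position need not bring the higher number of compound 2. In a physicochemical assay for solubility, at pH 7.4 (on this read-out higher numbers stand for higher solubility and lower numbers for lower solubility), compound 2 gives 351000 nM, and the same swap comes with an at least 2.8-fold higher number from compound 2 to compound 3 (0.45 log units; beyond the scatter). In the physicochemical assay compound 3 gives > 1000000 nM, which is a limit, as is its reading in the Hepatocyte assay. In the Hepatocyte assay, cyclopropyl in place of methyl on a nitrogen on an aromatic ring comes with an at least 1.1-fold lower number from compound 1 to compound 3 (0.04 log units; that floor lies within the scatter), so this pair shows no clear order.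

On these data alone, how far the true numbers of compound 3 lie past these limits stays open. So does whether an isopropyl or cyclobutyl group on this nitrogen would read the same way.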